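The compounds below may be only part of what the source reports. "The series", "measured", "known", "first", "only" and "open" are said of these compounds alone.

Compound 1 `COc1ccc(-c2cc3nccc(-c4cc(OC)c(OC)c(OC)c4)n3n2)cc1`: 376 nM in a functional assay on A549 cells (Homo sapiens) for inhibition, read by CCK-8 assay, with a stated time of 48 h; on this read-out lower numbers stand for stronger inhibition and higher numbers for weaker inhibition
Compound 2 `COc1cc(-c2ccnc3cc(-c4cn(C)c5ccccc45)nn23)cc(OC)c1OC`: 1340 nM in this assay

Compound 2 gives the higher of the two numbers, separated from compound 1 by a 3.6-fold higher number from compound 1 to compound 2 (0.55 log units; beyond the scatter). Compound 3 `C=Cc1ccc(-c2cc3nccc(-c4cc(OC)c(OC)c(OC)c4)n3n2)cc1` differs from compound 2 by 4-vinylphenyl in place of 1-methyl-1H-indol-3-yl on an aromatic carbon. For the measured compounds named here, the one measured step bearing on this change is a 3.6-fold higher number from compound 1 to compound 2 (0.55 log units; beyond the scatter), which brought in the 1-methyl-1H-indol-3-yl group and raised the number. The new change removes that group again in favour of a 4-vinylphenyl group that resembles the 4-methoxyphenyl of compound 1, so a drop of similar size back toward compound 1 is expected. Compound 3 is estimated to give 450 nM in this assay, between 150 nM and 1400 nM, a step of a 3.0-fold lower number from compound 2 to compound 3 (0.47 log units; beyond the scatter).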

Compound 3, half-maximal inhibitory concentration: 1030 nM
The estimate for compound 3 lay 2.3-fold (0.36 log units) below the measured number; the measured number falls inside the stated range.
By their numbers in this assay, from the lowest: compound 1; then compounds 3 and 2 (each within the scatter of the next).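

In this assay the change from 1-methyl-1H-indol-3-yl to 4-vinylphenyl gives a 1.3-fold lower number from compound 2 to compound 3 (0.11 log units; within the scatter) and so does not separate the two compounds. With the phenyl ring kept, vinyl in place of methoxy gives a 2.7-fold higher number from compound 1 to compound 3 (0.44 log units; beyond the scatter) and so a phenyl ring at this position does not alone match compound 1: the group it carries also counts. Nothing measured here gives a reason for this. Still open, as far as these compounds go, is how an amine, a carboxylic acid or a fluorine in place of methoxy would read. Also open, from the compounds shown here alone, is whether an ethyl group would behave like vinyl.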